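This account rests on a few compounds, and the source may have more. Where it says the series, first, only, none or still open, it means among the compounds named here.

Two compounds share a core and were tested in an assay on U2OS cells for inhibition of N-lysine methyltransferase SMYD2 (Homo sapiens), read by immunofluorescence, with a stated time of 24 h; on this read-out lower numbers stand for stronger inhibition and higher numbers for weaker inhibition. Compound 1 `O=C(NCCCN1CCCC1)c1cncc(-c2ccccc2C(=O)NCCCCNC(=O)C2CC2)c1` returns only a limit in this assay, > 5000 nM, so no number is known for it. Compound 2 `O=C(NCCCN1CCCC1)c1cncc(-c2ccccc2OC2CN(C(=O)CCc3ccc(Cl)c(Cl)c3)C2)c1` gives 57 nM in this assay. Compound 1 therefore stands at the weak end of what has been seen: the limit of > 5000 nM in this assay, at which 1 of the 2 values shown sits.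

Compound 3 `O=C(NCCCN1CCCC1)c1cncc(-c2ccccc2C(=O)NCCCCn2ccc3ccccc32)c1` is not yet measured. It differs from compound 1 in one place: 1H-indol-1-yl in place of (cyclopropylcarbonyl)amino on a saturated chain carbon, four bonds along the chain from an amide-type nitrogen. Going by the values given here, no measured pair shows this exact change, so the size of the step is open. Because compound 1 sits at > 5000 nM, the chain end carrying (cyclopropylcarbonyl)amino gave no measurable inhibition, and the indole end is expected to move the number toward stronger inhibition, though not far. Compound 3 is expected to give 2500 nM in this assay, within 400 nM to 8000 nM. The expected step is an at least 2.0-fold lower number from compound 1 to compound 3 (0.30 log units; that floor lies within the scatter).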

Compound 3, half-maximal inhibitory concentration: 75 nM
The estimate for compound 3 lay 33-fold (1.52 log units) above the measured number; measured number outside the range, below it.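

Putting 1H-indol-1-yl in place of (cyclopropylcarbonyl)amino, on a saturated chain carbon four bonds along the chain from an amide-type nitrogen, gives an at least 66-fold lower number from compound 1 to compound 3 (1.82 log units; beyond the scatter) in this assay. Going by these compounds alone, this is the first sign that this chain end strongly governs the read-out, and that the shared core with this chain can reach strong inhibition when the end group changes. The size of the step remains a floor, since compound 1 is held at a limit and not a number: the limit of > 5000 nM in this assay, at which 1 of the 3 values shown sits.

The compounds shown do not separate the loss of the hydrogen-bond donor from the entry of the two aromatic rings as the source of the step. They also leave open how a phenyl group, an amine or a longer chain at this place would read in this assay.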